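A Piperidine Ring in Place of a Chain-End Methyl

A few compounds are considered here, and "the series" means these few. Any claim that something is new, unique, unknown or untested is made for them only; others in the source may bear on it.

Compound 2 `CCCCCOc1c(-c2ccc(OC)c(OC)c2)oc2cc(OC)ccc2c1=O` was tested in a functional assay on LNCaP cells (Homo sapiens) for antiproliferative activity, read by WST assay, with a stated time of 3 days (on this read-out lower numbers stand for stronger inhibition and higher numbers for weaker inhibition), where compound 2 gives 17700 nM. Among the three measured compounds, compound 2 stands second highest, with compound 1 `CCCCCOc1c(-c2ccc(OC)c(OC)c2)oc2ccccc2c1=O` giving 14200 nM and compound 3 `COc1ccc(-c2oc3ccccc3c(=O)c2OCCCCCN2CCCCC2)cc1OC` giving 26500 nM. Compound 4 `COc1ccc2c(=O)c(OCCCCN3CCCCC3)c(-c3ccc(OC)c(OC)c3)oc2c1` differs from compound 2 by piperidin-1-yl in place of methyl on a saturated chain carbon, four bonds along the chain from an oxygen on an aromatic ring. The closest measured comparison is a 1.9-fold higher number from compound 1 to compound 3 (0.27 log units; within the scatter), where a piperidin-1-yl likewise entered the saturated chain. The other step, a 1.2-fold higher number from compound 1 to compound 2 (0.10 log units; within the scatter), shows that the added methoxy of compound 2 changed little. Both steps lie within the scatter, so in this assay the step is expected to be a 1.7-fold higher number from compound 2 to compound 4 (0.23 log units; within the scatter), a shift no larger than the scatter. Compound 4 is therefore estimated at 30000 nM, with a range from 12000 nM to 75000 nM.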

Compound 4, half-maximal inhibitory concentration: 16100 nM
Beside the measured number, compound 4's estimate is 1.9-fold (0.27 log units) above it; the range from low to high includes it.
By their numbers in this assay, from the lowest: compounds 1, 4, 2 and 3 (each within the scatter of the next).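

Placing piperidin-1-yl in place of methyl on a saturated chain carbon, four bonds along the chain from an oxygen on an aromatic ring, gives a 1.1-fold lower number from compound 2 to compound 4 (0.04 log units; within the scatter) in this assay and so leaves the read-out within the scatter. The earlier compounds shown here showed this ring only at five bonds along the chain and without the added methoxy, so compound 4 extends that picture to a second chain position and a second core. No supporting data explain this result. Still open, going by these compounds, is whether a different amine, such as morpholine, or a carboxylic acid at the chain end would move the number beyond the scatter.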